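The compounds below may be only part of what the source reports. "The series", "measured", "known", "first", "only" and "open" are said of these compounds alone.

Among the compounds with values here, compound 1 `CC(C)C[C@@H]1NC(=O)[C@H](C)NC1=O` is the smaller of the two compounds measured so far. Within the data shown here, in a functional assay, tested at 2.5 mM (a higher number here means more inhibition at the concentration tested (going by the name of the read-out), a lower number less inhibition), compound 1 gives 0%, which leaves it level with its only measured neighbour, compound 2 `CC(C)C[C@@H]1NC(=O)[C@H](Cc2cnc[nH]2)NC1=O`, which in this assay gives 0%. Among the measured compounds shown here, the single measured step, no change at the digits printed from compound 1 to compound 2 (within the scatter), put 1H-imidazol-5-yl in place of hydrogen on a saturated chain carbon bound to a saturated ring carbon and left the read-out where it was.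

The new compound, compound 3 `CC(C)C[C@@H]1NC(=O)[C@H](CCC(N)=O)NC1=O`, departs from compound 1 at the same place, on a saturated chain carbon bound to a saturated ring carbon, with a different group: carbamoylmethyl in place of hydrogen on a saturated chain carbon bound to a saturated ring carbon. For the measured compounds named here, the only step that bears on this change is the one to compound 2, which was within the scatter, and compound 1 itself shows no inhibition at the concentration tested. No step beyond the scatter is therefore expected here, in either direction. Compound 3 is expected to give 0% in this assay, within a range from -8% to 10%. The step of no change at the digits printed from compound 1 to compound 3 (within the scatter) that this estimate implies is expected to remain within the scatter.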

Compound 3, a percentage reported as inhibition, at one concentration (the size of the read-out at that concentration, not a potency): 0%
The estimate for compound 3 equals the measured number at the digits printed, within the range that was stated.
By their numbers in this assay, from the lowest: compounds 1, 2 and 3 (each within the scatter of the next).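

In this assay, a second group on the saturated chain carbon bound to a saturated ring carbon leaves the read-out where it was, with carbamoylmethyl in place of hydrogen giving no change at the digits printed from compound 1 to compound 3 (within the scatter) and carbamoylmethyl in place of 1H-imidazol-5-yl giving no change at the digits printed from compound 2 to compound 3 (within the scatter). The earlier compounds showed this only for a group with a ring, whereas carbamoylmethyl has no ring, so neither kind of group shown here moves the read-out in this assay from the level of compound 1, and compound 3 gives 0%. Nothing available accounts for this lack of change.

With all three compounds level, the series shows no group at this place that raises the read-out, and it cannot show a group that lowers it, since compound 1 already stands at 0%. Going by these compounds, whether an amine, a carboxylic acid or a longer chain at this place would lift the read-out in this assay above that of compound 1 remains open, as does whether any change elsewhere on the shared core would do so.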